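A few compounds are considered here, and "the series" means these few. Any claim that something is new, unique, unknown or untested is made for them only; others in the source may bear on it.

Compound 1, `CNC(=O)c1cc(C(=O)NC2CC2)cn(Cc2cccc3cc[nH]c23)c1=O`: 3.7
Compound 2, `CNC(=O)c1cc(C(=O)NC2CCOCC2)cn(Cc2ccccc2)c1=O`: 2.8
Compound 3, `CNC(=O)c1cc(C(=O)NCCOC)cn(Cc2ccccc2)c1=O`: 2.7

These three compounds share one core and were measured in a physicochemical assay for lipophilicity, at pH 7.4; a higher number here means a more lipophilic compound, a lower number a more polar compound. Compound 1 stands highest of the three; compound 2 lies nearest to it, and compound 3 lies furthest, both gaps being beyond the scatter. Within the data shown here, the only single-point step among the measured compounds is a number 0.10 log units lower from compound 2 to compound 3 (within the scatter), which concerns the amide side of the molecule rather than the group attached to the aromatic nitrogen.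

The unmeasured compound 4, `CNC(=O)c1cc(C(=O)NC2CC2)cn(Cc2cccc(C#N)c2)c1=O`, is derived from compound 1 by one change: 3-cyanophenyl in place of 1H-indol-7-yl on a saturated chain carbon bound to an aromatic nitrogen.

Among the measured compounds shown here, no measured step addresses this particular exchange. Compound 2 differs from compound 1 in two places at once, so its lower value cannot be assigned to either change alone. The expectation therefore rests only loosely on the comparison of compound 1 and compound 2, and is given with a wide range. Compound 4 is expected to sit below compound 1, a step estimated as a number 0.70 log units lower from compound 1 to compound 4 (beyond the scatter). The estimate for compound 4 is 3, expected to fall between 2.5 and 3.5.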

Compound 4, distribution coefficient: 2.6
Estimate against measurement, compound 4: 0.40 log units above; low and high end bracket the measured number.
By their numbers in this assay, from the lowest: compounds 4, 3 and 2 (each within the scatter of the next); then compound 1.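

In this assay, putting 3-cyanophenyl in place of 1H-indol-7-yl on the saturated chain carbon bound to the aromatic nitrogen gives a number 1.10 log units lower from compound 1 to compound 4 (beyond the scatter), with the rest of the molecule, including the cyclopropyl group on the amide, left unchanged. Among these compounds, the earlier compounds could not isolate this position: compound 1 and compound 2 differ in two places at once, and the one single-place step among them, a number 0.10 log units lower from compound 2 to compound 3 (within the scatter), lies on the amide side, whereas this large step shows that a change at this position alone can move the number well beyond the scatter. The two groups differ in their rings, in their hydrogen-bond donors and acceptors and in the triple bond, and nothing available here separates these differences or explains the size of the step.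

From the compounds shown here alone, it remains open whether the same exchange would give a step of similar size with oxan-4-yl or 2-methoxyethyl on the amide nitrogen. The compounds shown also leave open where a phenyl ring carrying a carboxylic acid or an amine in place of the nitrile would fall in this assay.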